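Methoxy removal from compound 2: working notes

The source may report more compounds than this note shows. Statements on the series, on what has been measured and on what is new or still open speak of the compounds shown alone.

- compound 1 `O=C(CCCCCCNC(=O)C(O)(O)C(F)(F)F)Nc1ncc(-c2ccc(Br)cc2)s1`: 790 nM
- compound 2 `COc1ccc2sc(NC(=O)CCCCCCNC(=O)C(O)(O)C(F)(F)F)nc2c1`: 810 nM
- compound 3 `O=C(CCCCCCNC(=O)C(O)(O)C(F)(F)F)Nc1ncc(-c2ccc(O)cc2)s1`: 1460 nM

All three values come from a functional assay on MDA-MB-231 cells (Homo sapiens) for inhibition, read by colorimetric assay, with a stated time of 3 days; on this read-out higher numbers stand for weaker inhibition and lower numbers for stronger inhibition. On these numbers, compound 2 lies within the scatter of both other compounds, so the three are not separated.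

The next compound is compound 4 `O=C(CCCCCCNC(=O)C(O)(O)C(F)(F)F)Nc1nc2ccccc2s1`, with hydrogen in place of methoxy on an aromatic carbon. For the measured compounds named here, no measured step covers this exchange on the core of compound 2. The nearest evidence is a 1.8-fold higher number from compound 1 to compound 3 (0.27 log units; within the scatter), a change of hydroxy in place of bromo on an aromatic carbon of another core. That step is small and stays within the scatter, and it is only indirect evidence here. No step beyond the scatter is therefore expected in this assay, and no firm direction can be assigned. The estimated change is a 1.2-fold higher number from compound 2 to compound 4 (0.07 log units; within the scatter). For compound 4 the expected value is 950 nM, with an estimated range of 450 nM to 2000 nM.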

Compound 4, half-maximal inhibitory concentration: 1830 nM
Compound 4: middle estimate off by 1.9-fold (0.28 log units), on the low side; the measured number falls inside the stated range.
By their numbers in this assay, from the lowest: compounds 1, 2, 3 and 4 (each within the scatter of the next, the first and the last beyond it).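

Taking the methoxy off this aromatic carbon of the six-membered ring gives a 2.3-fold higher number from compound 2 to compound 4 (0.35 log units; beyond the scatter) in this assay, the first step in the series to pass the scatter, although only modestly. The position on the core of compound 2 is therefore not indifferent to its substituent, and here the presence of methoxy goes with the lower number, whereas the hydroxy for bromo exchange on the other core, a 1.8-fold higher number from compound 1 to compound 3 (0.27 log units; within the scatter), stayed within the scatter. No measurement on hand accounts for this step.

With hydrogen and methoxy the only groups shown at this position, it remains open whether an ethoxy, a methyl, a chloro or an amine there would track with methoxy or with hydrogen. On these data alone, it also remains open whether the same exchange would give a step of similar size on another core.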